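The source may report more compounds than this note shows. Statements on the series, on what has been measured and on what is new or still open speak of the compounds shown alone.

The compounds measured so far:
Compound 1 `CCCCCCNc1nc(SCc2ccc(C(F)(F)F)cc2)nc2ccccc12`, which in a functional assay on MCF7 cells (Homo sapiens) for cytotoxicity, read by MTT assay, with a stated time of 72 h (a lower number here means a stronger inhibitor, a higher number a weaker inhibitor), gives 24300 nM.
Compound 2 `FC(F)(F)c1ccc(CSc2nc(Nc3cccc(C(F)(F)F)c3)c3ccccc3n2)cc1`, which in this assay gives 15300 nM.

Both compounds share one core and differ only in the group carried on a nitrogen on an aromatic ring: hexyl in compound 1, 3-(trifluoromethyl)phenyl in compound 2. Going by the values given here, that single step, a 1.6-fold lower number from compound 1 to compound 2 (0.20 log units; within the scatter), is the only comparison available, and it lies within the scatter. Compound 2 thus holds the lowest of the two numbers, but compound 1 cannot be called the weaker of the pair on this evidence.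

Compound 3 `O=[N+]([O-])c1ccc(Nc2nc(SCc3ccc(C(F)(F)F)cc3)nc3ccccc23)cc1` has not yet been measured. Against compound 2 the change is 4-nitrophenyl in place of 3-(trifluoromethyl)phenyl on a nitrogen on an aromatic ring. Among the compounds with values here, no measured step exchanges one aromatic group for another at this nitrogen; the only step available, from hexyl to an aromatic group, moved the number little. Nothing here points in either direction, so the expected step is a 1.0-fold lower number from compound 2 to compound 3 (0.01 log units; within the scatter), no larger than the scatter. Compound 3 is therefore estimated at 15000 nM in this assay, with a likely range from 5000 nM to 45000 nM.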

Compound 3, half-maximal inhibitory concentration: 17900 nM
For compound 3 the middle estimate is 1.2-fold (0.08 log units) below the measured one, within the range that was stated.
By their numbers in this assay, from the lowest: compounds 2, 3 and 1 (each within the scatter of the next).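

Going by these compounds alone, this is the first exchange of one aromatic group for another at this nitrogen: 4-nitrophenyl in place of 3-(trifluoromethyl)phenyl gives a 1.2-fold higher number from compound 2 to compound 3 (0.07 log units; within the scatter) in this assay, so these two substituted rings cannot be told apart here, even though they carry quite different groups. Within the data shown here, the comparison with the open chain reads a 1.4-fold lower number from compound 1 to compound 3 (0.13 log units; within the scatter), so a second aromatic group also fails to separate from hexyl, which the single step from compound 1 to compound 2 could not show alone. Hexyl and both aromatic groups therefore give numbers that lie within the scatter of one another, and no measurement at hand offers an explanation for this.

On these data alone, whether any group on this nitrogen can move the number beyond the scatter stays open, for example a much shorter chain such as methyl, or an aromatic ring carrying an amine or a carboxylic acid. The rest of the molecule is the same in all three compounds, so these results also say nothing about how changes elsewhere on the shared core would read in this assay.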